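The source may hold more compounds than are shown below. What is called first, only, known or untested is meant among the compounds shown, and "the series" means these compounds.

Measured compounds in an ADME assay on HEK293 cells (Homo sapiens) for inhibition, read by CellTiter-Glo, with a stated time of 96 h, tested at 100 uM; a lower number here means less inhibition, a higher number more inhibition at the concentration tested (going by the name of the read-out):
- compound 1 `COC(=O)/C=C\NC(=O)[C@H](O)C(C)(C)CO`: "not determined" (no result reported)
- compound 2 `CC(C)(C)OC(=O)/C=C\NC(=O)[C@H](O)C(C)(C)CO`: -9%
- compound 3 `CC(C)(CO)[C@@H](O)C(=O)N/C=C\C(=O)OCc1ccccc1`: 7%

Compound 1 stands without a number in this assay; for it only "not determined" (no result reported) is recorded, so there is no starting value for the step to compound 4. For the measured compounds named here, compound 2 gives -9% and compound 3 gives 7%; the one measured step, a number 16 percentage points higher from compound 2 to compound 3 (beyond the scatter), comes from a benzyl in place of tert-butyl on an oxygen next to a carbonyl group and is the only gauge of how far this series moves in this assay.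

Compound 4 `COC(=O)/C=C/NC(=O)[C@H](O)C(C)(C)CO` differs from compound 1 as follows: the two compounds have the same atoms and bonds and differ only in configuration as drawn: 1 of 2 stereo elements differ; a double bond is drawn Z in compound 1 and E in compound 4. Going by the values given here, no measured pair changes the configuration of a double bond, so none of the steps bears directly on this change. Among the compounds with values here, both measured readings sit at the low end of the inhibition scale, and the single measured step is modest. Compound 4 is therefore expected to read at a similarly low level, with no step beyond the scatter to be expected; the estimate for compound 4 is 0%, within -15% to 15%.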

Compound 4, a percentage reported as inhibition, at one concentration (the size of the read-out at that concentration, not a potency): 0%
Compound 4: the middle estimate sits on the measured number at the digits printed, and the stated range covers the measured number.
By their numbers in this assay, from the lowest: compounds 2, 4 and 3 (each within the scatter of the next, the first and the last beyond it).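

For the compounds shown here, compound 4 gives 0% while compound 1 stands at "not determined" (no result reported), so no step from compound 1 to compound 4 can be read. The compounds shown leave open whether Z or E configuration at the double bond shifts the reading at all.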